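Pyridin-2-yl in place of 3-chlorophenyl: compound 3

A few compounds are considered here, and "the series" means these few. Any claim that something is new, unique, unknown or untested is made for them only; others in the source may bear on it.

Measured so far:
compound 1, `CCCCCCCCc1ccc(OCC(=O)Cn2nnc(Cc3ccccc3)n2)cc1`, in an assay on microsomes from brain for inhibition of Fatty-acid amide hydrolase 1 (Rattus norvegicus), read by fluorescence and HPLC, with a stated time of 60 min; a higher number here means a weaker inhibitor, a lower number a stronger inhibitor: 66 nM
compound 2, `CCCCCCCCc1ccc(OCC(=O)Cn2nnnc2-c2cccc(Cl)c2)cc1`, in this assay: 360 nM

Among the compounds with values here, compound 2 gives the highest of the two numbers so far; its nearest neighbour, compound 1, sits at a lower number, and the gap between the two is beyond the scatter. The two compounds differ in more than one place, so the gap is not tied to a single change.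

Compound 3, `CCCCCCCCc1ccc(OCC(=O)Cn2nnnc2-c2ccccn2)cc1`, has not been measured. It differs from compound 2 in one place: pyridin-2-yl in place of 3-chlorophenyl on an aromatic carbon. Within the data shown here, no measured pair shows this exchange, so no step is known for it. Among the measured compounds shown here, the only anchor is compound 2 at 360 nM. The change removes the chlorine and brings one hydrogen-bond acceptor into the six-membered ring; no direction for this can be read from compound 1, whose difference from compound 2 lies elsewhere.

The step of a 1.4-fold higher number from compound 2 to compound 3 (0.14 log units; within the scatter) is expected to stay within the scatter, with a lean toward a somewhat higher number. Compound 3 is estimated at 500 nM, in the range 150 nM to 1600 nM.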

Compound 3, half-maximal inhibitory concentration: 880 nM
For compound 3 the middle estimate is 1.8-fold (0.25 log units) below the measured one; the range from low to high includes it.
By their numbers in this assay, from the lowest: compound 1; then compound 2; then compound 3.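

Pyridin-2-yl in place of 3-chlorophenyl gives the first single-place step in the series: in this assay the exchange on the aromatic carbon of the five-membered ring with 4 nitrogen brings a 2.4-fold higher number from compound 2 to compound 3 (0.39 log units; beyond the scatter), a modest move. The position therefore responds to this exchange, yet the aromatic group can change without the reading being lost, and compound 3 still gives 880 nM in this assay. The exchange removes the chlorine and brings in a ring nitrogen with its hydrogen-bond acceptor at the same time, so this single step cannot separate the two parts of the change. Nothing measured on the compounds bears on why the number rises.

Open, as far as these compounds go, is whether plain phenyl would read closer to compound 2 or to compound 3, which would show how much of the step belongs to the chlorine, and whether pyridin-3-yl or pyridin-4-yl would behave like pyridin-2-yl. Also open, from the compounds shown here alone, is whether the same exchange gives a similar step when the octyl chain is shortened or ends in a carboxylic acid.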